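The compounds below may be only part of what the source reports. "The series", "measured", "known", "first", "only" and "open" are said of these compounds alone.

Working notes on a pyrrole-carboxamide series, read in a toxicity assay on MT2 cells (Homo sapiens) for cytotoxicity, read by XTT assay, with a stated time of 4 days; on this read-out lower numbers stand for higher toxicity in this test and higher numbers for lower toxicity in this test.

Compound 1 `Cc1nc([C@@H](NC(=O)c2ccc(-c3ccc(Cl)c(F)c3)[nH]2)[C@@H]2CCCCN2)sc1CCO` gives 16900 nM in this assay. Compound 2 `Cc1nc([C@@H](NC(=O)c2ccc(-c3ccc(Cl)cc3)[nH]2)[C@@H]2CCCCN2)sc1CCO` carries hydrogen in place of fluoro on an aromatic carbon relative to compound 1; in this assay compound 2 gives 26800 nM, and the step of a 1.6-fold higher number from compound 1 to compound 2 (0.20 log units; within the scatter) is within the scatter, so the two numbers are read as equivalent.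

Compound 3 `Cc1nc([C@H](NC(=O)c2ccc(-c3ccc(Cl)c(F)c3)[nH]2)[C@@H]2CCCCN2)sc1CCCO` rests on a core that differs from that of compound 1 in more than one place; that difference between the two cores is not broken down here. In this assay compound 3 gives 12600 nM, within the scatter of compound 1 and beyond the scatter of compound 2.

Compound 4 `Cc1nc([C@H](NC(=O)c2ccc(-c3ccc(Cl)cc3)[nH]2)[C@@H]2CCCCN2)sc1CCCO` is not yet measured. It stands to compound 3 as compound 2 stands to compound 1: the change is hydrogen in place of fluoro on an aromatic carbon, and the place of the change reads the same in both pairs, so the change is taken as the same. Among the measured compounds shown here, the only measured instance of this change, from compound 1 to compound 2, moved the number by a 1.6-fold higher number from compound 1 to compound 2 (0.20 log units; within the scatter), which is within the scatter; on that basis a step of about a 1.6-fold higher number from compound 3 to compound 4 (0.20 log units; within the scatter) is expected from compound 3 to compound 4 in this assay, with wide uncertainty because only one pair supports it. Compound 4 is therefore estimated at 20000 nM in this assay, with a likely range from 10000 nM to 40000 nM.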

Compound 4, half-maximal cytotoxic concentration: 19000 nM
The estimate for compound 4 lay 1.1-fold (0.02 log units) above the measured number; low and high end bracket the measured number.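

In this assay, the change from 4-chloro-3-fluorophenyl to 4-chlorophenyl gives a 1.5-fold higher number from compound 3 to compound 4 (0.18 log units; within the scatter), and the two readings of this change agree: the same change on two cores in this assay, a 1.6-fold higher number (0.20 log units; within the scatter) from compound 1 to compound 2 and a 1.5-fold higher number (0.18 log units; within the scatter) from compound 3 to compound 4, 1.1-fold (0.02 log units) apart, within the scatter of two such steps Within these two pairs, then, the replacement of fluoro by hydrogen carries from one core to the other, with a step of matching size and direction on both and neither step clear of the scatter. This is agreement between two small steps, so it does not show that the fluoro group has a real effect on this read-out, and two pairs cannot show that the change would read the same on any other core in the series.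

On these data alone, all four compounds keep the chloro group, so it remains open how the same change would read with a trifluoromethyl group or a nitrile in its place. Also open, as far as these compounds go, is whether the change still reads the same when the chain ending in a hydroxyl group gives way to a carboxylic acid, an amine or a longer chain, and which of the several differences between the two cores matters to this assay.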